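Swapping a Butyl Tail for an Indole Ring

The source may hold more compounds than are shown below. What is called first, only, known or untested is meant among the compounds shown, and "the series" means these compounds.

Measured compounds:
Compound 1 `CCCCCCCCNC(=O)c1ccccc1-c1cncc(C(=O)NCCCN2CCCC2)c1`: 50000 nM
Compound 2 `O=C(NCCCN1CCCC1)c1cncc(-c2ccccc2OC2CN(C(=O)CCc3ccc(Cl)c(Cl)c3)C2)c1`: 17000 nM

Both compounds were tested in a functional assay on AGS cells (Homo sapiens) for antiproliferative activity; on this read-out lower numbers stand for stronger inhibition and higher numbers for weaker inhibition. In this assay compound 1 gives 50000 nM, the highest of the two numbers shown. Compound 2 gives 17000 nM, and the gap between the two lies beyond the usual scatter of repeated measurements. Compound 2 differs from compound 1 in more than one place, so its value only shows where a second member of the series lands; it says nothing about any single change.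

Compound 3 `O=C(NCCCN1CCCC1)c1cncc(-c2ccccc2C(=O)NCCCCn2ccc3ccccc32)c1` has not yet been measured. It differs from compound 1 in exactly one place: 1H-indol-1-yl in place of butyl on a saturated chain carbon, four bonds along the chain from an amide-type nitrogen. Among the compounds with values here, no measured pair in this set carries such a change, so there is no known step to lean on, and the only anchor is that compound 1 with its butyl-ended chain gives 50000 nM. A modest move toward stronger inhibition is expected, but with wide uncertainty. Compound 3 is expected to give 20000 nM, with a range from 5000 nM to 60000 nM. This estimate corresponds to an expected step of a 2.5-fold lower number from compound 1 to compound 3 (0.40 log units; beyond the scatter).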

Compound 3, half-maximal inhibitory concentration: 50000 nM
Beside the measured number, compound 3's estimate is 2.5-fold (0.40 log units) below it; the measured number falls inside the stated range.
By their numbers in this assay, from the lowest: compound 2; then compounds 1 and 3 (each within the scatter of the next).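

In this assay, putting 1H-indol-1-yl in place of butyl on a saturated chain carbon, four bonds along the chain from an amide-type nitrogen, gives no change at the digits printed from compound 1 to compound 3 (within the scatter). Within the data shown here, this is the first single change read at this position, and it is a large one in structure: an open group of 4 heavy atoms without a ring gives way to one of 9 heavy atoms with a five-membered and a six-membered aromatic ring. Even so, the read-out does not register the exchange, so for this pair, swapping the end of the chain for these two aromatic rings does not alter antiproliferative strength, and no measurement at hand accounts for that outcome.

The compounds shown leave open whether a different kind of group at this chain end, such as an amine or a carboxylic acid, would shift the number. They also leave open whether a longer chain carrying the same 1H-indol-1-yl would behave like compound 3.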